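Nitrophenyl placement on the chain aryl in a cytotoxicity series

The compounds below may be only part of what the source reports. "The series", "measured", "known", "first", "only" and "open" are said of these compounds alone.

Measured so far in a functional assay on HeLa cells (Homo sapiens) for cytotoxicity, read by WST assay, with a stated time of 48 h; a lower number here means a stronger inhibitor, a higher number a weaker inhibitor:
- compound 1 `Cc1ccc(/C=C/C[C@H]2C[C@@H]([C@@H](O)c3ccccc3)CO[C@@H]2c2ccccc2)cc1C` gives 10000 nM
- compound 2 `COc1ccc(/C=C/C[C@@H]2C[C@H]([C@H](O)c3ccc(OC)c(OC)c3)CO[C@H]2c2ccc(OC)c(OC)c2)cc1OC` gives 28700 nM
- compound 3 `O=[N+]([O-])c1ccccc1/C=C/C[C@H]1C[C@@H]([C@@H](O)c2ccccc2)CO[C@@H]1c1ccccc1` gives 11800 nM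

Compound 3 stands second highest of the three numbers, within the scatter of compound 1 and beyond the scatter of compound 2, which gives the higher number. The next compound, compound 4 `O=[N+]([O-])c1cccc(/C=C/C[C@H]2C[C@@H]([C@@H](O)c3ccccc3)CO[C@@H]2c2ccccc2)c1`, is compared with compound 3 by 3-nitrophenyl in place of 2-nitrophenyl on a double-bonded chain carbon bound to a double-bonded chain carbon. Among the compounds with values here, the only measured step at the same place is a 1.2-fold higher number from compound 1 to compound 3 (0.07 log units; within the scatter), which stayed within the scatter. Nothing measured shows the chain aryl moving the number beyond the scatter, so no step beyond the scatter is expected in this assay either way. The estimated step is a 1.0-fold higher number from compound 3 to compound 4 (0.01 log units; within the scatter). Compound 4 is expected to give 12000 nM, with a range from 5000 nM to 30000 nM.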

Compound 4, half-maximal inhibitory concentration: 7850 nM
Compound 4: middle estimate off by 1.5-fold (0.18 log units), on the high side; measured number inside the range.
By their numbers in this assay, from the lowest: compounds 4, 1 and 3 (each within the scatter of the next); then compound 2.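

In this assay at this place, on a double-bonded chain carbon bound to a double-bonded chain carbon, 3-nitrophenyl in place of 2-nitrophenyl stays within the scatter (a 1.5-fold lower number from compound 3 to compound 4 (0.18 log units; within the scatter)). 3-nitrophenyl in place of 3,4-dimethylphenyl also stays within the scatter (a 1.3-fold lower number from compound 1 to compound 4 (0.11 log units; within the scatter)). All three chain aryl groups on this shared core now read within the scatter of one another, so neither nitro placement separates from the dimethyl group.

On these data alone, whether an amine or a carboxylic acid on the chain aryl would give a step beyond the scatter remains open. No evidence is available on what lies behind these numbers.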